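The source may report more compounds than this note shows. Statements on the series, on what has been measured and on what is new or still open speak of the compounds shown alone.

Measured so far in a functional assay on the whole organism (strain albino) for inhibition, with Rattus norvegicus as the target, read by paw edema, with a stated time of 1 h, at a dose of 0.28 mmol/kg by the oral route; a higher number here means more inhibition at the dose given (going by the name of the read-out), a lower number less inhibition:

Compound 1, `C=CCn1c(SCC(=O)c2ccccc2)nnc1-c1ccccc1`: 43%
Compound 2, `CCn1c(SCC(=O)c2ccccc2)nnc1-c1ccccc1`: 52%
Compound 3, `CCn1c(SC/C(=N/O)c2ccccc2)nnc1-c1cc(OC)c(OC)c(OC)c1`: 63%

Compound 3 gives the highest number of the three in this assay ; its gaps to compound 2 and to compound 1 both lie beyond the scatter. Compound 4, `C=CCn1c(SC/C(=N/O)c2ccccc2)nnc1-c1cc(OC)c(OC)c(OC)c1`, is not yet measured. Compound 4 is obtained from compound 3 by the change (vinyl in place of methyl on a saturated chain carbon bound to an aromatic nitrogen). The same change, at the same place, is already on record between two measured compounds: compound 1 is obtained from compound 2 by vinyl in place of methyl on a saturated chain carbon bound to an aromatic nitrogen, and that step reads a number 9 percentage points lower from compound 2 to compound 1 (within the scatter), within the scatter. How the core of compound 2 differs from the core of compound 3 is not broken down here.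

For compound 4 a step of about the same size as the one already seen is expected, a number 8 percentage points lower from compound 3 to compound 4 (within the scatter), resting on a number 9 percentage points lower from compound 2 to compound 1 (within the scatter). On that basis compound 4 is estimated at 55% in this assay , with the expected range running from 40% to 68%.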

Compound 4, a percentage reported as inhibition, in the whole organism at one dose (the size of the read-out at that dose, not a potency): 61%
Estimate against measurement, compound 4: 6 percentage points below, and the stated range covers the measured number.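

In this assay, the change from ethyl to allyl on the core of compound 3 reads a number 2 percentage points lower from compound 3 to compound 4 (within the scatter). Set beside the earlier step, the change carries over from one core to the other without a detectable difference: the same change on two cores in this assay, a number 9 percentage points lower (within the scatter) from compound 2 to compound 1 and a number 2 percentage points lower (within the scatter) from compound 3 to compound 4, 7 percentage points apart, within the scatter of two such steps

Both steps lie within the scatter, so the two cores give no sign that this change moves the inhibition at this dose, but they also do not show that the change has no effect at all, nor that it would behave alike on a third core.

Open, from the compounds shown here alone, is what a longer chain such as butyl, or a chain ending in an amine or a carboxylic acid, would do in place of the ethyl on either core. Also open is whether ethyl and allyl stay level at other doses or times, since the readings shown come from one dose and one time and are not potencies.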